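From Chloro to Nitro at the Assay Limit

A few compounds are considered here, and "the series" means these few. Any claim that something is new, unique, unknown or untested is made for them only; others in the source may bear on it.

Three measured compounds frame this question. In a functional assay on A549 cells (Homo sapiens) for inhibition, read by MTT assay, with a stated time of 48 h (a higher number here means a weaker inhibitor, a lower number a stronger inhibitor), compound 1 `Brc1ccc2[nH]cc(C(c3c[nH]c4ccc(Br)cc34)C3CCCCC3)c2c1` gives 5500 nM. In this assay compound 2 `CCCCCCCC(c1c[nH]c2ccc([N+](=O)[O-])cc12)c1c[nH]c2ccc([N+](=O)[O-])cc12` gives 12500 nM. Compound 3 `N#Cc1ccc2[nH]cc(C(c3ccc(Cl)cc3)c3c[nH]c4ccc(C#N)cc34)c2c1` returns no number, only a limit of > 100000 nM. Compound 3 therefore stands at the limit of > 100000 nM in this assay, at which 1 of the 3 values shown sits.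

Compound 4 `N#Cc1ccc2[nH]cc(C(c3ccc([N+](=O)[O-])cc3)c3c[nH]c4ccc(C#N)cc34)c2c1` keeps the structure of compound 3 except for one change, from 4-chlorophenyl to 4-nitrophenyl: nitro in place of chloro on an aromatic carbon, para to a large group (nitro in place of chloro on an aromatic carbon). Going by the values given here, no two measured compounds differ in one place, so the data give no direct measure of any single change.

In this assay only a modest step is expected, and compound 4 may well reach the limit too. Any step that yields a number would run toward a stronger inhibitor, since the expectation starts from compound 3 with its limit of > 100000 nM. The estimated step is an at least 1.4-fold lower number from compound 3 to compound 4 (0.15 log units; that floor lies within the scatter), and it is rough because one end is a limit. For compound 4 the expected value is 70000 nM, with an estimated range of 20000 nM to 150000 nM.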

Compound 4, half-maximal inhibitory concentration: > 100000 nM
Compound 4: no number, only a limit (the forecaster's own chance of this, stated with the estimate: 55%); middle value at least 1.4-fold (0.15 log units) from the limit.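

In this assay, compound 3 and compound 4 both return only a limit rather than a number, so no step between them can be read: the limit of > 100000 nM in this assay, at which 2 of the 4 values shown sit.

The compounds shown leave open what nitro in place of chloro on an aromatic carbon does to inhibition, and how far past the limit either compound lies.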